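This account rests on a few compounds, and the source may have more. Where it says the series, first, only, none or still open, it means among the compounds named here.

Working notes, a physicochemical assay for lipophilicity; on this read-out higher numbers stand for higher lipophilicity and lower numbers for lower lipophilicity:

- compound 1 `O=S(=O)(Nc1ncccn1)c1ccc2c(c1)CC[C@@H]2c1ccc(C(F)(F)F)cc1-c1ccc(F)nc1`: 3.2
- compound 2 `O=S(=O)(Nc1nccs1)c1ccc2c(c1)OCC[C@@H]2c1ccc(C(F)(F)F)cc1-c1ccc(F)cc1`: 4.5
- compound 3 `O=S(=O)(Nc1nccs1)c1ccc2c(c1)OCC[C@H]2c1ccc(C(F)(F)F)cc1-c1ccc(F)cc1`: 4.5

Compound 2, at 4.5, is level with compound 3 at the top of this small set, and compound 1 stands clearly lower at 3.2.

The next compound to be measured is compound 4 `O=C1COCCN1c1cc(C(F)(F)F)ccc1[C@H]1CCOc2cc(S(=O)(=O)Nc3nccs3)ccc21`. In it, 3-oxomorpholin-4-yl takes the place of 4-fluorophenyl on an aromatic carbon, ortho to a large group and meta to a trifluoromethyl group: 3-oxomorpholin-4-yl in place of 4-fluorophenyl on an aromatic carbon.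

Within the data shown here, the only measured step, no change at the digits printed from compound 2 to compound 3 (within the scatter), involves configuration alone (the fact that compounds 2 and 3 differ only in the configuration as drawn). It therefore gives no size for an exchange of groups, and the expectation rests on the structural change itself. An aromatic ring of carbon only leaves, and a non-aromatic ring with hetero atoms and hydrogen-bond acceptors enters. A clear downward step in this assay, beyond the scatter, is expected from the level of compound 2 at 4.5.

The expected step is a number 1.40 log units lower from compound 2 to compound 4 (beyond the scatter).

For compound 4 the estimated value is 3.1, with an expected range of 2.5 to 3.7.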

Compound 4, distribution coefficient: 1.8
Beside the measured number, compound 4's estimate is 1.30 log units above it; the whole stated range lies above it.
By their numbers in this assay, from the lowest: compound 4; then compound 1; then compounds 2 and 3 (each within the scatter of the next).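

At the aromatic carbon ortho to a large group and meta to a trifluoromethyl group, this assay responds strongly to an exchange of groups, with 3-oxomorpholin-4-yl in place of 4-fluorophenyl: the change is a number 2.70 log units lower from compound 2 to compound 4 (beyond the scatter). Among these compounds, the earlier pair varied only the configuration at a saturated ring carbon, with no change at the digits printed from compound 2 to compound 3 (within the scatter), so this is the first size available for a change of group at this position. Both groups carry 7 heavy atoms, so the step goes with a six-membered aromatic ring of carbon only giving way to a non-aromatic ring with 2 hetero atoms and 2 hydrogen-bond acceptors, but nothing measured here assigns a cause.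

A single exchange does not separate the part played by the carbonyl from that of the ring oxygen or the ring nitrogen. Going by these compounds, whether morpholin-4-yl without the carbonyl, or piperidin-1-yl, would give a step of similar size at this place remains open.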